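Bromo to fluoro swap on two related cores

A few compounds are considered here, and "the series" means these few. Any claim that something is new, unique, unknown or untested is made for them only; others in the source may bear on it.

Two pairs of compounds are compared in a functional assay on MCF7 cells (Homo sapiens) for antiproliferative activity, read by MTT assay, with a stated time of 72 h; on this read-out higher numbers stand for weaker inhibition and lower numbers for stronger inhibition. Compound 1 `COc1ccc(/C=C2/CN(C)/C(=N/c3ccc(Br)cc3)S2)cc1` gives 7400 nM in this assay. Compound 2 `COc1ccc(/C=C2/CN(C)/C(=N/c3ccc(F)cc3)S2)cc1` differs from compound 1 by fluoro in place of bromo on an aromatic carbon, and in this assay compound 2 gives 8000 nM. The halogen swap therefore produces a 1.1-fold higher number from compound 1 to compound 2 (0.03 log units; within the scatter), so the two values cannot be told apart.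

Compound 3 `COc1ccc(/C=C2\S/C(=N\c3ccc(Br)cc3)N(C)C2=O)cc1` is built on a different core; the difference between the two cores is not broken down here. In this assay compound 3 reaches only a limit, > 100000 nM. Among the compounds with values here, the assay thus reports no number for compound 3, only that its value lies beyond the range covered.

Compound 4 `COc1ccc(/C=C2\S/C(=N\c3ccc(F)cc3)N(C)C2=O)cc1` is not yet measured in this assay. Relative to compound 3 it carries fluoro in place of bromo on an aromatic carbon, which is the same change, at the same kind of place, as the one that turns compound 1 into compound 2. The step from compound 3 to compound 4 is expected to be a step that the limit leaves unreadable from compound 3 to compound 4, because the same change gave a 1.1-fold higher number from compound 1 to compound 2 (0.03 log units; within the scatter) on the other core, and because compound 3 already sits at the limit of > 100000 nM in this assay, at which 1 of the 3 values shown sits. Compound 4 is accordingly estimated at 150000 nM, with a plausible range from 50000 nM to 500000 nM, and is most likely to come back as a limit rather than a number.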

Compound 4, half-maximal inhibitory concentration: 66500 nM
Beside the measured number, compound 4's estimate is 2.3-fold (0.35 log units) above it; the measured number falls inside the stated range.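

On the core of compound 3, the change from 4-bromophenyl to 4-fluorophenyl in this assay gives an at least 1.5-fold lower number from compound 3 to compound 4 (0.17 log units; that floor lies within the scatter), and that figure is only a floor, not a measured size of the step. Set beside the core of compound 1, this result neither shows that the change carries over from one core to the other nor shows that the two cores respond differently: the same change on two cores in this assay, a 1.1-fold higher number (0.03 log units; within the scatter) from compound 1 to compound 2 and an at least 1.5-fold lower number (0.17 log units; that floor lies within the scatter) from compound 3 to compound 4; the limit leaves it open whether they differ. Compound 3 carries only a limit of the assay, > 100000 nM, and the true size of the step on its core stays unread, so the flat result for the same swap on the core of compound 1 cannot be taken as a rule for the series.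

The compounds shown hold only bromo and fluoro at this place on the aromatic ring, which leaves open how chloro, a nitrile or an amine there would read in this assay on either core. Also open, as far as these compounds go, is how either core would read with the methyl group on nitrogen replaced by an ethyl group or a longer chain.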